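Removing the Carbonyl from Compound 1

The compounds below may be only part of what the source reports. "The series", "measured", "known", "first", "only" and "open" are said of these compounds alone.

Compound 1 `CCN1CCN(C(=O)c2ccc(Nc3ncc4c(n3)N(C)C(=O)N(c3cc(NC(=O)c5cccc(C(F)(F)F)c5)ccc3C)C4)cn2)CC1` gives 24.2%
Compound 2 `Cc1ccc(Nc2ncc3c(n2)N(C)C(=O)N(c2cc(NC(=O)c4ccc(CN5CCC(N(C)C)C5)c(C(F)(F)F)c4)ccc2C)C3)cn1` gives 58.7%

Among the compounds with values here, in an ADME assay on microsomes from liver (Mus musculus) for metabolic stability, with a stated time of 30 min, tested at 1 uM (a lower number here means that less of the compound is left, a higher number that more of the compound is left), compound 1 (24.2%) holds the lower of the two numbers measured so far. Compound 2 (58.7%) lies higher, and the gap between them is beyond the scatter. Compound 2 differs from compound 1 in several places, so this gap says little about any single change.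

Compound 3 `CCN1CCN(c2ccc(Nc3ncc4c(n3)N(C)C(=O)N(c3cc(NC(=O)c5cccc(C(F)(F)F)c5)ccc3C)C4)cn2)CC1` has not yet been measured. It carries 4-ethylpiperazin-1-yl in place of (4-ethylpiperazin-1-yl)carbonyl on an aromatic carbon of a six-membered aromatic ring with 1 nitrogen (4-ethylpiperazin-1-yl in place of (4-ethylpiperazin-1-yl)carbonyl on an aromatic carbon). Within the data shown here, no pair of measured compounds differs in one place only, so no measured step can guide this comparison. The expectation therefore starts from compound 1 (24.2%) and stays close to it. In this assay the estimated step (a number 4.2 percentage points lower from compound 1 to compound 3 (within the scatter)) is small and downward, and it is not expected to pass beyond the scatter. For compound 3 an estimated 20% is expected, with 6% to 42% as the expected range.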

Compound 3, percent of the compound remaining: 21.2%
For compound 3 the middle estimate is 1.2 percentage points below the measured one; the measured number falls inside the stated range.
By their numbers in this assay, from the lowest: compounds 3 and 1 (each within the scatter of the next); then compound 2.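

In this assay, within the data shown here, the printed step for taking the carbonyl out, so that 4-ethylpiperazin-1-yl sits directly on the aromatic carbon next to the ring nitrogen, is a number 3 percentage points lower from compound 1 to compound 3 (within the scatter); this is the first comparison that differs in one place only. It shows that at this position the carbonyl can be removed, taking the group from 10 heavy atoms to 8 and dropping its double bond outside aromatic rings, without the percent of compound remaining moving beyond the scatter, while the count of hydrogen-bond acceptors in the group stays the same. Nothing measured here gives a reason for this result.

The compounds shown leave open whether a different link at this place, such as a methylene group or an ether oxygen, or a different group on the piperazine nitrogen, such as a methyl group or a hydroxyethyl chain, would give a step beyond the scatter. They also leave open whether removing the carbonyl would give a similar step if the benzamide part carried an added amine.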